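A few compounds are considered here, and "the series" means these few. Any claim that something is new, unique, unknown or untested is made for them only; others in the source may bear on it.

Compound 2 `CNCc1cn(S(=O)(=O)c2cc(OC)ccn2)c(-c2cccnc2F)c1F` gives 95% in a functional assay on the whole organism (strain Jcl:Sprague-Dawley) for inhibition, with Rattus norvegicus as the target, with stated times of 3 min and 3 h, at a dose of 1 mg/kg by the intravenous route (a higher number here means more inhibition at the dose given (going by the name of the read-out), a lower number less inhibition), the lower of the two numbers recorded, though compound 1 `CNCc1cc(-c2cccnc2F)n(S(=O)(=O)c2cccnc2)c1`, which gives 96% in this assay, sits within the scatter of it, so the two numbers are level and neither can be said to be higher than the other. Compound 3 `CNCc1cn(S(=O)(=O)c2cnccc2C)c(-c2cccnc2F)c1F` carries 4-methylpyridin-3-yl in place of 4-methoxypyridin-2-yl on a sulfonyl sulfur. Among the compounds with values here, no measured pair shows the effect of this change, so no step beyond the scatter is expected from compound 2 to compound 3 in this assay, and the expected shift is a number 5 percentage points lower from compound 2 to compound 3 (within the scatter). Compound 3 is therefore estimated at 90%, with a range from 72% to 99%.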

Compound 3, a percentage reported as inhibition, in the whole organism at one dose (the size of the read-out at that dose, not a potency): 98%
Estimate against measurement, compound 3: 8 percentage points below; measured number inside the range.
By their numbers in this assay, from the lowest: compounds 2, 1 and 3 (each within the scatter of the next).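

On a sulfonyl sulfur, 4-methylpyridin-3-yl takes the place of 4-methoxypyridin-2-yl with a number 3 percentage points higher from compound 2 to compound 3 (within the scatter) in this assay and no step beyond the scatter. Within the data shown here, this is the first reading at this position, and it shows that this one pyridine group can be exchanged for the other while the inhibition stays level at the dose given. Nothing measured bears on why the two groups read alike. Open, as far as these compounds go, is whether a group without a ring nitrogen, such as phenyl, or a saturated amine such as piperidin-1-yl, would hold the inhibition on this sulfur.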